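The compounds below may be only part of what the source reports. "The series", "measured", "known", "first", "only" and "open" are said of these compounds alone.

Measured compounds, values in a functional assay on A549 cells (Homo sapiens) for cytotoxicity, read by crystal violet staining, with a stated time of 3 days; a higher number here means a weaker inhibitor, a lower number a stronger inhibitor:

Compound 1 `COc1cc2c(cc1OC)C(/C(C)=N/NC(N)=S)N(S(=O)(=O)c1ccc(C)cc1)CC2`: > 50 ug/mL, a limit of the assay.
Compound 2 `COc1ccc(S(=O)(=O)N2CCc3cc(OC)c(OC)cc3C2/C(C)=N/NC(N)=S)cc1`: > 50 ug/mL, a limit of the assay.
Compound 3 `C/C(=N\NC(N)=S)C1c2ccccc2CCN1S(=O)(=O)c1ccc(C)cc1`: > 50 ug/mL, a limit of the assay.

Compound 3 stands at the same limit as the other two members; none of the three gives a number in this assay, and compound 3 cannot be placed relative to compound 1 or compound 2 beyond that. The step that the two limits leave unreadable from compound 1 to compound 2 is therefore unreadable, since both ends are limits (the limit of > 50 ug/mL in this assay, at which 3 of the 3 values shown sit).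

Compound 4 `C/C(=N\NC(N)=S)C1c2ccccc2CCN1S(=O)(=O)c1ccc([N+](=O)[O-])cc1` differs from compound 3 by nitro in place of methyl on an aromatic carbon. For the measured compounds named here, no measured step bears on this change: the one step concerns a different substituent and is itself unreadable. With every value in the series sitting at the limit (the limit of > 50 ug/mL in this assay, at which 3 of the 3 values shown sit), there is no basis to expect a step beyond the scatter in this assay in either direction, and a further limit is the most likely outcome. The step from compound 3 to compound 4 is estimated as a number no higher from compound 3 to compound 4 (the limit leaves the size open). Compound 4 is thus expected near 50 ug/mL, with a range from 15 ug/mL to 100 ug/mL.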

Compound 4, half-maximal inhibitory concentration: > 50 ug/mL
Compound 4 ended at the assay's limit (the forecaster's own chance of this, stated with the estimate: 70%); the middle value sits exactly at the limit.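

Compound 3 and compound 4 both stand at a limit in this assay, so no step can be read between them: the limit of > 50 ug/mL in this assay, at which 4 of the 4 values shown sit.

The compounds shown leave open how large the nitro-for-methyl change is, and whether any compound on this shared core gives a readable value in this assay at all.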